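From phenoxy to vinyl on the side chain

This account rests on a few compounds, and the source may have more. Where it says the series, first, only, none or still open, it means among the compounds named here.

Compound 1 `COCCOc1ccc(C(O)C2OC(=O)c3c(OC)cc(OC)cc32)cc1`: > 40000 nM
Compound 2 `COCCCCOc1ccc(C(O)C2OC(=O)c3c(OC)cc(OC)cc32)cc1`: > 40000 nM
Compound 3 `COc1cc(OC)c2c(c1)C(C(O)c1ccc(OCCOc3ccccc3)cc1)OC2=O`: > 40000 nM

These three compounds share one core and differ in the group carried on the chain. They were tested in an ADME assay on RAW264.7 cells (Mus musculus) for cytotoxicity, read by MTT assay, with a stated time of 24 h, in the absence of a further agent; on this read-out higher numbers stand for weaker inhibition and lower numbers for stronger inhibition. In this assay compound 3 gives > 40000 nM, which is a limit and not a number. For the measured compounds named here, it has no readable place among the others, for the series so far shows (the limit of > 40000 nM in this assay, at which 3 of the 3 values shown sit).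

The next compound is compound 4 `C=CCCOc1ccc(C(O)C2OC(=O)c3c(OC)cc(OC)cc32)cc1`, and the change that leads to it is vinyl in place of phenoxy on a saturated chain carbon, two bonds along the chain from an oxygen on an aromatic ring. Vinyl thus takes the place of phenoxy on a saturated chain carbon, two bonds along the chain from an oxygen on an aromatic ring.

The nearest measured change at that place is a step that the two limits leave unreadable from compound 2 to compound 3. The other two are a step that the two limits leave unreadable from compound 1 to compound 3 and a step that the two limits leave unreadable from compound 1 to compound 2. None of these has a size that can be read, so they offer no measured effect to carry over. All three chain ends nevertheless left their compounds at the limit, so no step beyond the scatter is expected in this assay, in either direction. The expected outcome is a step that the limit leaves unreadable from compound 3 to compound 4. For compound 4 the estimate is 45000 nM, with an expected range from 25000 nM to 80000 nM.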

Compound 4, half-maximal inhibitory concentration: > 40000 nM
Compound 4: no number, only a limit; the forecaster's own chance of this, stated with the estimate: 85%; the middle value lies beyond the limit too.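

In this assay compound 4 gives > 40000 nM, which is a limit and not a number, so its steps from compound 1, compound 2 and compound 3 cannot be read. The series now stands as follows: the limit of > 40000 nM in this assay, at which 4 of the 4 values shown sit.

The compounds shown leave open how these four chain ends rank against one another, and whether any group at this place would give a readable value in this assay.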